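Cytotoxicity of a hydrazone series: changing the aryl group

This account rests on a few compounds, and the source may have more. Where it says the series, first, only, none or still open, it means among the compounds named here.

Of the compounds shown here, three sharing one core have been tested in an ADME assay on NIH3T3 cells (Mus musculus) for cytotoxicity, read by MTT assay, with a stated time of 24 h; a higher number here means a weaker inhibitor, a lower number a stronger inhibitor. Compound 1 `O=C(CSc1nnc(-c2ccncc2)o1)N/N=C/c1ccccc1` gives 167000 nM. Compound 2 `O=C(CSc1nnc(-c2ccncc2)o1)N/N=C/c1ccc([N+](=O)[O-])cc1` gives 195000 nM. Compound 3 `O=C(CSc1nnc(-c2ccncc2)o1)N/N=C/c1cccc(F)c1` gives 205000 nM, the highest of the three numbers, though its neighbours sit within the scatter. Compound 4 `O=C(CSc1nnc(-c2ccncc2)o1)N/N=C/c1cc(Br)cc(Br)c1O` differs from compound 3 in one place: 3,5-dibromo-2-hydroxyphenyl in place of 3-fluorophenyl on a carbon with a double bond to nitrogen. Two measured steps change the same aryl group on the carbon with a double bond to nitrogen: a 1.2-fold higher number from compound 1 to compound 3 (0.09 log units; within the scatter) and a 1.1-fold higher number from compound 2 to compound 3 (0.02 log units; within the scatter). Neither swap of a substituent on that ring moved the number beyond the scatter, so for compound 4 no step beyond the scatter is expected in this assay, even though the entering group brings bromine and a hydroxyl that the measured steps never tested. The number for compound 4 is estimated at 190000 nM, with a range from 90000 nM to 400000 nM, which is expected to amount to a 1.1-fold lower number from compound 3 to compound 4 (0.03 log units; within the scatter).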

Compound 4, half-maximal inhibitory concentration: 190000 nM
For compound 4 middle estimate and measured number coincide at the digits printed; measured number inside the range.
By their numbers in this assay, from the lowest: compounds 1, 4, 2 and 3 (each within the scatter of the next).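

In this assay, putting 3,5-dibromo-2-hydroxyphenyl on the carbon with a double bond to nitrogen gives a 1.1-fold lower number from compound 3 to compound 4 (0.03 log units; within the scatter) and a 1.0-fold lower number from compound 2 to compound 4 (0.01 log units; within the scatter) and a 1.1-fold higher number from compound 1 to compound 4 (0.06 log units; within the scatter) and so leaves all four compounds within the scatter of one another. The earlier compounds shown here tried only a fluoro or a nitro on this ring, whereas this group brings two bromines and a hydroxyl with a hydrogen-bond donor that 3-fluorophenyl lacks, and still no step stands out. Nothing available explains why the number stays level across these groups.

The compounds shown leave open whether an amine or a carboxylic acid on this ring, or a longer chain in place of the ring, would move the number beyond the scatter. The shared core is the same in all four compounds, so what a change there would do cannot be read.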